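A few compounds are considered here, and "the series" means these few. Any claim that something is new, unique, unknown or untested is made for them only; others in the source may bear on it.

Measured compounds:
- compound 1, `c1ccc2c(-c3cn4ccnc4c(-c4ccc5ncn(C6CCCCC6)c5c4)n3)cccc2c1`: 4.11%
- compound 2, `COc1ccccc1-c1cn2ccnc2c(-c2ccc3ncn(C4CCCCC4)c3c2)n1`: 11.1%
- compound 3, `Fc1ccccc1-c1cn2ccnc2c(-c2ccc3ncn(C4CCCCC4)c3c2)n1`: 7.26%

In a functional assay on HT-29 cells (Homo sapiens) for inhibition, read by sulforhodamine B assay, with a stated time of 48 h, tested at 10 uM (on this read-out lower numbers stand for less inhibition and higher numbers for more inhibition at the one concentration tested (going by the name of the read-out)), compound 3 has the second highest of the three numbers. Its closest neighbour is compound 1, with a step of a number 3.2 percentage points higher from compound 1 to compound 3 (within the scatter); the step of a number 3.8 percentage points lower from compound 2 to compound 3 (within the scatter) is the larger of the two, yet both lie within the scatter, so the three compounds cannot be told apart on this read-out.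

Compound 4, `c1csc(-c2cn3ccnc3c(-c3ccc4ncn(C5CCCCC5)c4c3)n2)c1`, is not yet measured. It differs from compound 3 in one place: thiophen-2-yl in place of 2-fluorophenyl on an aromatic carbon. All three measured steps change the group on that same aromatic carbon, so all of them bear on this change. Each of them, a number 7 percentage points higher from compound 1 to compound 2 (within the scatter), a number 3.2 percentage points higher from compound 1 to compound 3 (within the scatter) and a number 3.8 percentage points lower from compound 2 to compound 3 (within the scatter), stayed within the scatter, even though the groups exchanged differ widely in size and in the atoms they carry. Nothing here points to a move in either direction, so the step of a number 0.3 percentage points lower from compound 3 to compound 4 (within the scatter) is expected to stay within the scatter. Compound 4 is therefore estimated at 7%, with a range from 0% to 18%.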

Compound 4, a percentage reported as inhibition, at one concentration (the size of the read-out at that concentration, not a potency): 0.09%
For compound 4 the middle estimate is 6.9 percentage points above the measured one; low and high end bracket the measured number.
By their numbers in this assay, from the lowest: compounds 4, 1, 3 and 2 (each within the scatter of the next, the first and the last beyond it).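

In this assay, among the compounds shown here, thiophen-2-yl gives the first step at this aromatic carbon that goes beyond the scatter (a number 11 percentage points lower from compound 2 to compound 4 (beyond the scatter)), so a change of group here can register on this read-out, if only modestly. This holds for one pair only, as the same group stays within the scatter against its other two neighbours (a number 7.2 percentage points lower from compound 3 to compound 4 (within the scatter); a number 4 percentage points lower from compound 1 to compound 4 (within the scatter)), so compound 4 cannot be placed below all the others. No measurement at hand explains the gap between the 2-methoxyphenyl and thiophen-2-yl groups.

As far as these compounds go, every group compared here is an uncharged aromatic ring, so it remains open whether an amine, a carboxylic acid or a longer alkyl chain on this carbon would move the number further. With a single tested concentration, the values also leave open how potent any of these compounds is, since they give only the size of the inhibition at that one concentration.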